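This account rests on a few compounds, and the source may have more. Where it says the series, first, only, none or still open, it means among the compounds named here.

Compound 3 `Cc1nc(N2CCCC2)c2nnn(-c3ccc(C(C)C)cc3Br)c2n1` is one of three compounds whose binding has been measured in an in vitro assay on 293-EBNA cells for binding affinity to corticotropin-releasing factor receptor 1 (Homo sapiens); a higher number here means a weaker inhibitor, a lower number a stronger inhibitor. Compound 3 gives 194 nM, the second highest of the three numbers. Compound 1 `CCCCN(CC)c1nc(C)nc2c1nnn2-c1c(C)cc(C)cc1C` gives 27.5 nM, a lower number than compound 3, while compound 2 `COCCNc1nc(C)nc2c1nnn2-c1c(C)cc(C)cc1C` gives 1200 nM, a higher number than compound 3. Compound 4 `CCC(Nc1nc(C)nc2c1nnn2-c1ccc(C(C)C)cc1Br)C(=O)OC` is not yet measured; it differs from compound 3 in one place, (a group of 8 heavy atoms (5 carbon, 1 nitrogen, 2 oxygen; no ring) in place of a group of 5 heavy atoms (4 carbon, 1 nitrogen; one five-membered non-aromatic ring with 1 hetero atom), on an aromatic carbon).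

For the measured compounds named here, the one measured step that bears on this change is the step from compound 1 to compound 2, where a tertiary amino group with two alkyl chains gave way to a smaller secondary amino group carrying an oxygen, and this assay moved by a 44-fold higher number from compound 1 to compound 2 (1.64 log units; beyond the scatter). The change from compound 3 to compound 4 likewise trades a tertiary amino group for a secondary one that brings a hydrogen-bond donor and extra acceptors, so a step of comparable size toward a higher number is expected, a 9.3-fold higher number from compound 3 to compound 4 (0.97 log units; beyond the scatter). Compound 4 is therefore estimated at 1800 nM, with a range from 450 nM to 7000 nM.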

Compound 4, inhibition constant: 19.4 nM
For compound 4 the middle estimate is 93-fold (1.97 log units) above the measured one, outside the stated range (below it).
By their numbers in this assay, from the lowest: compounds 4 and 1 (each within the scatter of the next); then compound 3; then compound 2.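

With a 10-fold lower number from compound 3 to compound 4 (1.00 log units; beyond the scatter) in this assay the result shows that, on this aromatic carbon next to the ring nitrogen, an open-chain secondary amino group carrying a methyl ester can give a lower number than pyrrolidin-1-yl. The earlier step of a 44-fold higher number from compound 1 to compound 2 (1.64 log units; beyond the scatter) also put a secondary amino group in place of a tertiary one yet ran the other way, so across these two steps the swap has no single direction, and a hydrogen-bond donor on that nitrogen does not by itself go with a higher number. No measurement shown accounts for the difference between the two steps.

The compounds shown do not separate the methyl ester from the branched chain that carries it, and a carboxylic acid or a primary amide in its place would bear on that. Also open, on these data alone, is whether the same group gives a similar step on the core of compound 1.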